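Working notes on the step from compound 2 to compound 4

The source may hold more compounds than are shown below. What is called first, only, known or untested is meant among the compounds shown, and "the series" means these compounds.

Measured compounds in an assay on HEK293 cells for negative allosteric modulation of metabotropic glutamate receptor 5 (Homo sapiens), read by FLIPR; a higher number here means a weaker inhibitor, a lower number a stronger inhibitor:
- compound 1, `O=C(c1ccc(Cl)cc1)N1CC(c2nc(-c3cccc(F)c3)no2)C1`, reported only as a limit of the assay: > 10000 nM
- compound 2, `O=C(N1CCC(F)CC1)N1CC(c2nc(-c3cccc(Cl)c3)no2)C1`, reported only as a limit of the assay: > 10000 nM
- compound 3, `Cc1ccc(C(=O)N2CC(c3nc(-c4cccc(F)c4)no3)C2)cc1`, reported only as a limit of the assay: > 10000 nM

All three measured values sit at the same limit, as summarised in the limit of > 10000 nM in this assay, at which 3 of the 3 values shown sit. For the measured compounds named here, the single step between measured compounds that differ in one place, a step that the two limits leave unreadable from compound 1 to compound 3, is therefore unreadable, since both of its ends are limits. Compound 2 stands at that limit of this assay together with the other two; no number separates it from them.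

Compound 4, `COC1CCCN(C(=O)N2CC(c3nc(-c4cccc(Cl)c4)no3)C2)C1`, differs from compound 2 by 3-methoxypiperidin-1-yl in place of 4-fluoropiperidin-1-yl on a carbonyl carbon. Going by the values given here, no measured step touches the group on the carbonyl carbon: the only measured step concerns an aromatic carbon and could not be read. Nothing measured thus points to a direction in this assay for the change from the 4-fluoropiperidin-1-yl to the 3-methoxypiperidin-1-yl group. The expectation rests solely on the fact that every value shown is a limit, (the limit of > 10000 nM in this assay, at which 3 of the 3 values shown sit). Compound 4 is expected to remain at that limit, with an expected step of a number no higher from compound 2 to compound 4 (the limit leaves the size open) that is none beyond the scatter. Compound 4 is estimated at 10000 nM, within a range from 3000 nM to 30000 nM, and a limit rather than a number is the expected report.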

Compound 4, half-maximal inhibitory concentration: 1830 nM
Estimate against measurement, compound 4: 5.5-fold (0.74 log units) above; measured number below the stated range.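

In this assay, for the compounds shown here, the group on the carbonyl carbon proves able to move the read-out: 3-methoxypiperidin-1-yl in place of 4-fluoropiperidin-1-yl gives an at least 5.4-fold lower number from compound 2 to compound 4 (0.73 log units; beyond the scatter) and so provides the first readable step, whereas the earlier step at the aromatic carbon cannot be read. The value of compound 2, > 10000 nM, is a limit of the assay, so the step has a known minimum but no fixed size. Compound 4 is the only compound shown with a number, and the other compounds remain at one limit: the limit of > 10000 nM in this assay, at which 3 of the 4 values shown sit.

From the compounds shown here alone, it remains open whether the step depends on the methoxy group itself, on its location in the piperidine ring, or simply on the loss of the fluorine, and a 4-methoxypiperidin-1-yl, an unsubstituted piperidin-1-yl or a morpholin-4-yl group on the same carbonyl carbon would help separate these readings. Going by these compounds alone, the single pair also leaves open whether the hydrogen-bond acceptor counted in the entering group has any part in the step, and a 3-ethylpiperidin-1-yl group would test that.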